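Swapping Dimethylamino for Chloro in a Weak Rat Inhibitor

The source may report more compounds than this note shows. Statements on the series, on what has been measured and on what is new or still open speak of the compounds shown alone.

Of the compounds shown here, two have so far been tested in a functional assay with Rattus norvegicus as the target; a higher number here means a weaker inhibitor, a lower number a stronger inhibitor. Compound 1 `CN(C)c1cccc(C(=O)/C=C/c2ccncc2)c1` gives 19000 nM in this assay, the lower of the two numbers. Compound 2 `O=C(/C=C/c1ccncc1)c1ccco1` gives 50000 nM in this assay, which lies beyond the scatter above the number for compound 1. Both numbers mark weak inhibition.

Compound 3 `O=C(/C=C/c1ccncc1)c1cccc(Cl)c1` has not yet been measured. It differs from compound 1 as follows: chloro in place of dimethylamino on an aromatic carbon. Among the compounds with values here, no pair of measured compounds differing in just one place exists, so there is no measured step to lean on, and the gap between compound 1 and compound 2 comes from a different kind of change that cannot be carried over. In this assay compound 3 is expected to give 20000 nM, with a range from 6000 nM to 60000 nM. That estimate amounts to an expected step of a 1.1-fold higher number from compound 1 to compound 3 (0.02 log units; within the scatter), which stays within the scatter.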

Compound 3, half-maximal inhibitory concentration: 69000 nM
Beside the measured number, compound 3's estimate is 3.5-fold (0.54 log units) below it; measured number above the stated range.
By their numbers in this assay, from the lowest: compound 1; then compounds 2 and 3 (each within the scatter of the next).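

On this aromatic carbon, the group present does matter. In this assay, within the data shown here, chloro in place of dimethylamino gives a 3.6-fold higher number from compound 1 to compound 3 (0.56 log units; beyond the scatter) and provides the first measured change in a single place, with the lower number belonging to the compound that carries dimethylamino. Among these compounds, the step is modest and shows only that this one swap moves the number beyond the scatter, while no measurement available here bears on the reason for it.

Going by these compounds, it remains open whether an amino group, a methoxy group or a methyl group on the same aromatic carbon would give a number closer to that of compound 1 or of compound 3. Also open, on these data alone, is whether the same swap would give a similar step at another position on the ring.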